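Shifting the oxane attachment within the ether side chain

The source may hold more compounds than are shown below. What is called first, only, known or untested is meant among the compounds shown, and "the series" means these compounds.

The series shares one core; compound 1 `CN(C)CCCNc1ccc(S(=O)(=O)NC(=O)c2ccc(N3CCN(CC4=C(c5ccc(C(F)(F)F)cc5)CC(C)(C)CC4)CC3)cc2Oc2cnc3[nH]ccc3c2)cc1[N+](=O)[O-]`, compound 2 `CC1(C)CCC(CN2CCN(c3ccc(C(=O)NS(=O)(=O)c4ccc(NCC5CCOC5)c([N+](=O)[O-])c4)c(Oc4cnc5[nH]ccc5c4)c3)CC2)=C(c2ccc(C(F)(F)F)cc2)C1` and compound 3 `CC1(C)CCC(CN2CCN(c3ccc(C(=O)NS(=O)(=O)c4ccc(OCC5CCOCC5)c([N+](=O)[O-])c4)c(Oc4cnc5[nH]ccc5c4)c3)CC2)=C(c2ccc(C(F)(F)F)cc2)C1` have been run in an assay on isolated protein for displacement of a labelled ligand from Apoptosis regulator Bcl-2 (Homo sapiens), with a stated time of 15 min; on this read-out higher numbers stand for weaker inhibition and lower numbers for stronger inhibition. Compound 1 gives 0.89 nM, compound 2 gives 4.7 nM, and compound 3 gives 1 nM. On these numbers compound 3 stands second highest of three: its nearest neighbour is compound 1, within the scatter, and its furthest is compound 2, which lies higher beyond the scatter.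

Compound 4 `CC1(C)CCC(CN2CCN(c3ccc(C(=O)NS(=O)(=O)c4ccc(OCC5CCCOC5)c([N+](=O)[O-])c4)c(Oc4cnc5[nH]ccc5c4)c3)CC2)=C(c2ccc(C(F)(F)F)cc2)C1` differs from compound 3 by oxan-3-yl in place of oxan-4-yl on a saturated chain carbon bound to an oxygen on an aromatic ring. Among the compounds with values here, none of the measured steps covers this kind of change. The step of a 5.3-fold higher number from compound 1 to compound 2 (0.72 log units; beyond the scatter) and the step of a 4.7-fold lower number from compound 2 to compound 3 (0.67 log units; beyond the scatter) exchange the whole terminal group of the side chain, and the step of a 1.1-fold higher number from compound 1 to compound 3 (0.05 log units; within the scatter) replaces the amine-linked chain by the ether-linked one. Together they show that the side chain can move the number by modest amounts at most, and that the ether-linked oxane chain sits close to the best value seen, but they give no direct read on moving the ring attachment by one position. The step in this assay from compound 3 to compound 4 is therefore expected to be small, a 1.5-fold higher number from compound 3 to compound 4 (0.18 log units; within the scatter), with direction uncertain. Compound 4 is estimated at 1.5 nM, with a range from 0.5 nM to 5 nM.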

Compound 4, half-maximal inhibitory concentration: 3 nM
Compound 4: the middle estimate sits 2.0-fold (0.30 log units) below what was measured, within the range that was stated.
By their numbers in this assay, from the lowest: compounds 1 and 3 (each within the scatter of the next); then compounds 4 and 2 (each within the scatter of the next).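

Moving the ring attachment alone, with the same atoms and the same ether link, is enough to shift the number in this assay (here a 3.0-fold higher number from compound 3 to compound 4 (0.48 log units; beyond the scatter)), so this position responds to where the oxane ring is joined and not only to the linker or to the terminal group as a whole. The ether link does not by itself keep a compound level with the amine-linked dimethylamino chain, since compound 3 lay within the scatter of compound 1, whereas the oxan-3-yl isomer does not (a 3.4-fold higher number from compound 1 to compound 4 (0.53 log units; beyond the scatter)), and it cannot be told apart from the amine-linked oxolane chain (a 1.6-fold lower number from compound 2 to compound 4 (0.19 log units; within the scatter)). Nothing available on these compounds accounts for the difference between the oxan-4-yl and oxan-3-yl attachments.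

As far as these compounds go, one pair of isomers is a thin basis, and it remains open whether the same step would appear with an amine-linked (oxan-3-yl)methyl chain. Also open, from the compounds shown here alone, is how the ether chain would read with oxan-2-yl, oxolan-3-yl or a piperidin-4-yl ring at the end of the same chain.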